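A Vinyl Analogue in a Series Stuck at the Limit

The source may hold more compounds than are shown below. What is called first, only, known or untested is meant among the compounds shown, and "the series" means these compounds.

Compound 1 `C/C(=C\c1cc(-c2ccccc2)cs1)C(N)=O`, compound 2 `C/C(=C\c1cc(-c2ccc(C)cc2)cs1)C(N)=O` and compound 3 `C/C(=C\c1cc(-c2ccc(C(F)(F)F)cc2)cs1)C(N)=O` share one core and differ only in the group on the six-membered aromatic ring of carbon only. In a functional assay on HO8910 cells (Homo sapiens) for cytotoxicity, read by CCK-8 assay, with a stated time of 24 h (a higher number here means a weaker inhibitor, a lower number a stronger inhibitor), compound 1 reports only the limit > 50000 nM and no number. Compound 2 likewise reaches only the limit > 50000 nM in this assay. Compound 3 too stands at the limit > 50000 nM, so no number is known for it either. The steps a step that the two limits leave unreadable from compound 1 to compound 2, a step that the two limits leave unreadable from compound 1 to compound 3 and a step that the two limits leave unreadable from compound 2 to compound 3 cannot be read, since all three values sit together at the limit of > 50000 nM in this assay, at which 3 of the 3 values shown sit. Compound 4 `C=Cc1ccc(-c2csc(/C=C(\C)C(N)=O)c2)cc1` carries vinyl in place of trifluoromethyl on an aromatic carbon. For the measured compounds named here, none of the measured steps gives a readable size for a change of the group at this site, and the three limits show no measurable inhibition anywhere. Compound 4 is therefore expected to give 60000 nM, in a range from 20000 nM to 200000 nM. The step that the limit leaves unreadable from compound 3 to compound 4 implied by this estimate is expected to be no larger than the scatter.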

Compound 4, half-maximal inhibitory concentration: > 50000 nM
Compound 4 was reported as a limit (the forecaster's own chance of this, stated with the estimate: 80%); the middle value does not contradict the limit.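

In this assay compound 4 gives > 50000 nM, a limit and not a number. Its steps to compound 1, compound 2 and compound 3 therefore cannot be read: the limit of > 50000 nM in this assay, at which 4 of the 4 values shown sit.

The compounds shown leave open whether any group at this site gives a measurable value in this assay.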